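This account rests on a few compounds, and the source may have more. Where it says the series, first, only, none or still open, it means among the compounds named here.

In a functional assay on A549 cells (Homo sapiens) for antiproliferative activity, read by MTT assay, with a stated time of 72 h (a lower number here means a stronger inhibitor, a higher number a weaker inhibitor), compound 1 `Nc1ccccc1NC(=O)CCCCCCc1nc(-c2ccc(C(F)(F)F)cc2)no1` gives > 100000 nM, which is a limit of the assay and not a number. Among the measured compounds shown here, compound 2 `Nc1ccccc1NC(=O)CCCCCCc1nc(-c2cccc([N+](=O)[O-])c2)no1` gives 20200 nM, the only exact number so far. Compound 3 `O=C(CCCCCCc1nc(-c2cccc([N+](=O)[O-])c2)no1)C(F)(F)F` carries trifluoromethyl in place of (2-aminophenyl)amino on a carbonyl carbon. For the measured compounds named here, the one measured step, an at least 4.9-fold lower number from compound 1 to compound 2 (0.69 log units; beyond the scatter), was made on an aromatic carbon, so it bears only loosely on this change, though it shows that this assay can respond to a single substitution. A modest move towards weaker inhibition is expected, with the estimated step being a 2.2-fold higher number from compound 2 to compound 3 (0.35 log units; beyond the scatter). For compound 3 the estimated value is 45000 nM, within an expected range of 12000 nM to 100000 nM.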

Compound 3, half-maximal inhibitory concentration: 9580 nM
Compound 3: the middle estimate sits 4.7-fold (0.67 log units) above what was measured; measured number below the stated range.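

The carbonyl carbon at the end of the chain is a second place where this assay responds, and trifluoromethyl in place of (2-aminophenyl)amino gives a 2.1-fold lower number from compound 2 to compound 3 (0.32 log units; beyond the scatter). The earlier step touched only an aromatic carbon. With the 3-nitrophenyl group kept, the six-membered aromatic ring of (2-aminophenyl)amino is therefore not required for the activity seen here.

As far as these compounds go, whether a hydroxyamino or methyl group on this carbonyl carbon would do better remains open. So does how trifluoromethyl behaves alongside 4-(trifluoromethyl)phenyl, the group of compound 1, whose value is a limit: the limit of > 100000 nM in this assay, at which 1 of the 3 values shown sits.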